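Opening a Lactam Ring: What to Expect for Compound 3

The source may report more compounds than this note shows. Statements on the series, on what has been measured and on what is new or still open speak of the compounds shown alone.

Measured so far:
compound 1 `CCn1ncc2c(F)cc(-c3ccc(C(CC)(CC)c4nncn4C)c(=O)[nH]3)cc21` gives 2.67 h
compound 2 `CC(C)C(c1ccc(-c2ccc3cccc(F)c3c2)[nH]c1=O)N1CCCCC1=O` gives 0.183 h

In an ADME assay on microsomes from liver (Homo sapiens) for metabolic stability (on this read-out lower numbers stand for a shorter-lived compound and higher numbers for a longer-lived compound), compound 2 stands at 0.183 h, the lowest of the two numbers; the nearest, compound 1, stands at 2.67 h, a gap beyond the scatter. Compound 3 `CC(C)NC(=O)CC(c1ccc(-c2ccc3cccc(F)c3c2)[nH]c1=O)C(C)C` has not yet been measured. It differs from compound 2 in one place: (isopropylcarbamoyl)methyl in place of 2-oxopiperidin-1-yl on a saturated chain carbon bound to an aromatic carbon and a saturated chain carbon. Within the data shown here, no measured pair shows this change, so the expectation rests on compound 2 alone. A modest upward step a 1.6-fold higher number from compound 2 to compound 3 (0.21 log units; within the scatter) is expected, barely beyond the scatter. Compound 3 is therefore estimated at 0.3 h, within a range from 0.1 h to 0.9 h.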

Compound 3, half-life: 0.32 h
The estimate for compound 3 lay 1.1-fold (0.03 log units) below the measured number; the range from low to high includes it.
By their numbers in this assay, from the lowest: compounds 2 and 3 (each within the scatter of the next); then compound 1.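

In this assay the swap of 2-oxopiperidin-1-yl for (isopropylcarbamoyl)methyl on this saturated chain carbon gives a 1.7-fold higher number from compound 2 to compound 3 (0.24 log units; within the scatter) and so the read-out does not separate the closed ring from the open chain. The open chain has no ring and brings a hydrogen-bond donor, yet compound 2 and compound 3 remain within the scatter of each other. Nothing at hand gives a reason for this result. Still open, from the compounds shown here alone, is whether a different group on this carbon, such as a carboxylic acid or an amine, would move the half-life beyond the scatter.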